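Ring-nitrogen substituent changes on the shared core

The compounds below may be only part of what the source reports. "The series", "measured", "known", "first", "only" and "open" are said of these compounds alone.

Measured so far in a functional assay on HT-29 cells (Homo sapiens) for cytotoxicity, read by MTT assay, with a stated time of 24 h, tested at 6.4 ug/mL; on this read-out lower numbers stand for a weaker effect and higher numbers for a stronger effect at the one concentration tested:
- compound 1 `CN1CCN(CC(=O)Nc2ccc(-c3nc(-c4ccccc4)c(-c4ccccc4)n3C)cc2)CC1` gives 28.8%
- compound 2 `CN(C)/C=C/N1CCN(CC(=O)Nc2ccc(-c3nc(-c4ccccc4)c(-c4ccccc4)n3C)cc2)CC1` gives 12.2%
- compound 3 `Cn1c(-c2ccc(NC(=O)CN3CCN(c4ccccc4)CC3)cc2)nc(-c2ccccc2)c1-c1ccccc1` gives 46.5%

Compound 3 stands highest of the three numbers in this assay ; its nearest neighbour is compound 1, with a number 17.7 percentage points higher from compound 1 to compound 3 (beyond the scatter), and the furthest is compound 2, with a number 34.3 percentage points higher from compound 2 to compound 3 (beyond the scatter). The third measured step, a number 16.6 percentage points lower from compound 1 to compound 2 (beyond the scatter), shows that exchanging the group on the amine nitrogen in the ring can move the read-out in either direction by a modest amount.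

Compound 4 `Cn1c(-c2ccc(NC(=O)CN3CCN(Cc4ccccc4)CC3)cc2)nc(-c2ccccc2)c1-c1ccccc1` is not yet measured. It differs from compound 3 in one place: benzyl in place of phenyl on an amine nitrogen in a ring. Among the compounds with values here, no measured pair covers a phenyl to benzyl exchange at this position, so the steps that bear on it only indirectly are a number 17.7 percentage points higher from compound 1 to compound 3 (beyond the scatter) and a number 16.6 percentage points lower from compound 1 to compound 2 (beyond the scatter), each modest in size. On that basis the step of a number 8.5 percentage points lower from compound 3 to compound 4 (within the scatter) is expected to stay within the scatter or fall slightly, since the nearest measured alternatives to phenyl at this nitrogen gave lower numbers. Compound 4 is therefore estimated at 38%, with a range from 20% to 56%.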

Compound 4, a percentage reported as activity, at one concentration (the size of the read-out at that concentration, not a potency): 26.8%
Estimate against measurement, compound 4: 11.2 percentage points above; the range from low to high includes it.
By their numbers in this assay, from the lowest: compound 2; then compounds 4 and 1 (each within the scatter of the next); then compound 3.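

Both compound 3 and compound 4 carry a six-membered aromatic ring of carbon only on the amine nitrogen in the ring, yet in this assay the change from phenyl to benzyl gives a number 19.7 percentage points lower from compound 3 to compound 4 (beyond the scatter), so the presence of that ring alone does not set the read-out. Benzyl does not keep the number seen with phenyl: a number 2 percentage points lower from compound 1 to compound 4 (within the scatter), placing it level with the methyl of compound 1, while a number 14.6 percentage points higher from compound 2 to compound 4 (beyond the scatter). Nothing measured on these compounds accounts for the phenyl to benzyl step.

From the compounds shown here alone, whether a longer chain such as 2-phenylethyl would follow benzyl, or whether a phenyl carrying chlorine or methoxy would hold or exceed the number of compound 3, remains open. All of these readings come from a single concentration, so they show only a stronger or weaker effect at that concentration.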